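Two Esters at the Ceiling, a Third Variant Awaits Testing

The compounds below may be only part of what the source reports. "The series", "measured", "known", "first", "only" and "open" are said of these compounds alone.

Compound 1 `CC1=CC[C@H]2[C@@H]1CC=C(C)[C@@H](CC[C@H]1[C@]3(C)CC[C@H](OC(=O)c4ccc(C)cc4)C(C)(C)O[C@H]3CC[C@@]1(C)O)C2(C)C` and compound 2 `CC1=CC[C@H]2[C@H](CC[C@]2(C)O)C(C)(C)[C@@H]1CC[C@H]1[C@]2(C)CC[C@H](OC(=O)NS(=O)(=O)c3ccc(C)cc3)C(C)(C)O[C@H]2CC[C@@]1(C)O` share most of their framework and differ mainly in the group carried on the ester carbonyl. In a functional assay on MCF7 cells (Homo sapiens) for antiproliferative activity, read by MTT assay, with a stated time of 72 h (a higher number here means a weaker inhibitor, a lower number a stronger inhibitor), compound 1 gives only a limit, > 50000 nM, not a number. Compound 2 likewise gives only a limit in this assay, > 50000 nM. Both results therefore sit at the limit of > 50000 nM in this assay, at which 2 of the 2 values shown sit, so neither compound shows measurable inhibition here.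

Compound 3 `CC1=CC[C@H]2[C@H](CC[C@]2(C)O)C(C)(C)[C@@H]1CC[C@H]1[C@]2(C)CC[C@H](OC(=O)c3ccccc3[N+](=O)[O-])C(C)(C)O[C@H]2CC[C@@]1(C)O` differs from compound 2 in a single place: 2-nitrophenyl in place of ((4-methylphenyl)sulfonyl)amino on a carbonyl carbon. Within the data shown here, no two measured compounds differ in just one place, so no measured step guides how large this change might be. Because compound 2 reaches only a limit, > 50000 nM, the step that the limit leaves unreadable from compound 2 to compound 3 is expected to be none beyond the scatter. Compound 3 is estimated at 60000 nM, in a range from 20000 nM to 200000 nM.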

Compound 3, half-maximal inhibitory concentration: 5200 nM
Estimate against measurement, compound 3: 12-fold (1.06 log units) above, outside the stated range (below it).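

Among these compounds, the group on this carbonyl carbon can decide whether any activity is seen at all: compound 3 is the first compound here to give a real number rather than a limit. In this assay, 2-nitrophenyl in place of ((4-methylphenyl)sulfonyl)amino gives an at least 9.6-fold lower number from compound 2 to compound 3 (0.98 log units; beyond the scatter). Compound 2 gives > 50000 nM, which is a limit and not a number, so this step is only a minimum and its full size cannot be read: the limit of > 50000 nM in this assay, at which 2 of the 3 values shown sit.

The change swaps the whole group at once, so these compounds cannot show whether the gain comes from the nitro group, the plain aromatic ring on the carbonyl carbon, or the loss of the sulfonylamino link. Going by these compounds, how an amine or a carboxylic acid would behave in place of the nitro group also remains open.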